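Returning the imidazole to the piperazine arm

The compounds below may be only part of what the source reports. "The series", "measured", "known", "first", "only" and "open" are said of these compounds alone.

Of the compounds shown here, three sharing one core have been tested in an assay on isolated protein for displacement of a labelled ligand from Gonadotropin-releasing hormone receptor (Homo sapiens); on this read-out higher numbers stand for weaker inhibition and lower numbers for stronger inhibition. Compound 1 `Cc1nc(CN2CCN(c3cccc4[nH]c(-c5ccc(C(C)(C)C)cc5)nc34)CC2)c[nH]1` gives 7.5 nM, compound 2 `CCc1nc(C)c(CN2CCN(c3cccc4[nH]c(-c5ccc(C(C)(C)C)cc5)nc34)CC2)s1` gives 20 nM, and compound 3 `Cc1cc(CN2CCN(c3cccc4[nH]c(-c5ccc(C(C)(C)C)cc5)nc34)CC2)nn1C` gives 83 nM. Compound 3 therefore stands highest of the three: the steps to it are an 11-fold higher number from compound 1 to compound 3 (1.04 log units; beyond the scatter) and a 4.2-fold higher number from compound 2 to compound 3 (0.62 log units; beyond the scatter), both beyond the scatter, so on these numbers it is the weakest binder shown.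

The next compound, compound 4 `CCCn1cc(CN2CCN(c3cccc4[nH]c(-c5ccc(C(C)(C)C)cc5)nc34)CC2)nc1C`, changes compound 3 in one place: 2-methyl-1-propyl-1H-imidazol-4-yl in place of 1,5-dimethyl-1H-pyrazol-3-yl on a saturated chain carbon bound to an amine nitrogen in a ring

The step that bears most directly on this is an 11-fold higher number from compound 1 to compound 3 (1.04 log units; beyond the scatter), since compound 1 carries a 2-methyl-1H-imidazol-4-yl at the same place and compound 4 carries a closely related 2-methyl-1-propyl-1H-imidazol-4-yl. The move from compound 1 to compound 3 raised the number strongly, so undoing much of that change is expected to lower it again. Among the measured compounds shown here, no compound shows what a propyl on the imidazole nitrogen does on its own, which leaves some uncertainty. Compound 4 is therefore expected to land at about 15 nM, somewhere between 5 nM and 50 nM, an estimated step of a 5.5-fold lower number from compound 3 to compound 4 (0.74 log units; beyond the scatter).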

Compound 4, half-maximal inhibitory concentration: 18 nM
Estimate against measurement, compound 4: 1.2-fold (0.08 log units) below, within the range that was stated.
By their numbers in this assay, from the lowest: compound 1; then compounds 4 and 2 (each within the scatter of the next); then compound 3.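

Placing propyl on the aromatic nitrogen of the imidazole gives the first direct reading of that change: a 2.4-fold higher number from compound 1 to compound 4 (0.38 log units; beyond the scatter) is a modest rise, so in this assay the substituted imidazole keeps binding in the low range seen for this set. The move from the pyrazole to the propyl imidazole gives a 4.6-fold lower number from compound 3 to compound 4 (0.66 log units; beyond the scatter) even though the two groups have matching counts of hydrogen-bond donors and acceptors, so those counts alone do not set the number at this position. With a 1.1-fold lower number from compound 2 to compound 4 (0.05 log units; within the scatter) inside the scatter, the thiazole of compound 2 and the propyl imidazole of compound 4 cannot be told apart.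

Nothing shown explains why these groups differ. On these data alone, it remains open how a methyl, an ethyl, a butyl or a propyl ending in an amine on that imidazole nitrogen would compare.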